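Aryl exchange on the shared core: growth inhibition notes

The compounds below may be only part of what the source reports. "The series", "measured", "known", "first", "only" and "open" are said of these compounds alone.

Measured in a functional assay on NCI-H23 cells (Homo sapiens) for inhibition; a lower number here means a stronger inhibitor of growth, a higher number a weaker inhibitor of growth:
- compound 1 `COc1cc(/C=C/C(=O)c2cccc(-n3cc(-c4ccc(Cl)cc4)[nH]c3=O)c2)cc(OC)c1OC`: 3560 nM
- compound 2 `COc1cc(/C=C/C(=O)c2cccc(-n3cc(-c4ccccc4)[nH]c3=O)c2)ccc1O`: 2020 nM

In this assay, for the measured compounds named here, compound 1 at 3560 nM and compound 2 at 2020 nM lie within the scatter of each other, so compound 1 stands level with the only other measured compound. Compound 3 `COc1cc(/C=C/C(=O)c2cccc(-n3cc(-c4cc(OC)c(OC)c(OC)c4)[nH]c3=O)c2)cc(OC)c1OC` is not yet measured. Relative to compound 1, it carries 3,4,5-trimethoxyphenyl in place of 4-chlorophenyl on an aromatic carbon of a five-membered aromatic ring with 2 nitrogen (3,4,5-trimethoxyphenyl in place of 4-chlorophenyl on an aromatic carbon). The rest of the structure is unchanged.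

Going by the values given here, the series contains no measured step between compounds that differ in one place, so the size of this exchange cannot be read from the data. No step beyond the scatter is therefore expected in this assay, and no direction is favoured with confidence. The expected change is a 1.3-fold lower number from compound 1 to compound 3 (0.10 log units; within the scatter), and this estimate remains uncertain. The value estimated for compound 3 is 2800 nM, with an expected range of 900 nM to 8500 nM.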

Compound 3, concentration for 50% growth inhibition: 2000 nM
Compound 3: middle estimate off by 1.4-fold (0.15 log units), on the high side, and the stated range covers the measured number.
By their numbers in this assay, from the lowest: compounds 3, 2 and 1 (each within the scatter of the next).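

The step of a 1.8-fold lower number from compound 1 to compound 3 (0.25 log units; within the scatter) in this assay gives this series its first comparison in which only one place differs, on an aromatic carbon of the five-membered aromatic ring with 2 nitrogen. Compound 1 and compound 3 stand level, although 3,4,5-trimethoxyphenyl brings 12 heavy atoms and 3 hydrogen-bond acceptors where 4-chlorophenyl has 7 heavy atoms and 0 hydrogen-bond acceptors. At this position, then, the exchange of one of these substituted phenyl groups for the other gives no step beyond the scatter, and no information at hand accounts for that result.

As far as these compounds go, both groups in this step are substituted phenyl rings, so it remains open whether a primary amine or a carboxylic acid on the same carbon would give a step beyond the scatter. From the compounds shown here alone, compound 2 differs from compound 1 and compound 3 in more than one place, so the separate contribution of its unsubstituted phenyl group and of the hydroxy and methoxy pattern on its other aryl ring also remains open.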